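This account rests on a few compounds, and the source may have more. Where it says the series, first, only, none or still open, it means among the compounds named here.

Measured in a functional assay on MGC-803 cells (Homo sapiens) for inhibition, read by sulforhodamine B assay; a higher number here means a weaker inhibitor, a lower number a stronger inhibitor:
- Compound 1 `CCc1ccc(NC2=CC(=O)c3c(nc4n3[C@H]3OC[C@@H](O)[C@H]3OC4)C2=O)cc1`: 1110 nM
- Compound 2 `O=C1C(N2CCCC2)=CC(=O)c2c1nc1n2[C@H]2OC[C@@H](O)[C@H]2OC1`: > 16000 nM

The entry for compound 2 is a limit of the assay and not a number. Compound 2 sits at the limit of > 16000 nM in this assay, at which 1 of the 2 values shown sits, so its true position is not known.

The next compound, compound 3 `O=C1C(N2CCCCC2)=CC(=O)c2c1nc1n2[C@H]2OC[C@@H](O)[C@H]2OC1`, has piperidin-1-yl in place of pyrrolidin-1-yl on a double-bonded ring carbon. One ring on the shared core is simply replaced by another non-aromatic ring.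

Going by the values given here, only one measured step bears on this change, and it is large and beyond the scatter: an at least 14-fold higher number from compound 1 to compound 2 (1.15 log units; beyond the scatter). It shows that the group at this place can matter a great deal. Among the compounds with values here, compound 3, like compound 2, lacks the (4-ethylphenyl)amino group, and no measured step compares two such non-aromatic rings. No step beyond the scatter is therefore expected in this assay, and the assay may well report only a limit again. The expected step is a step that the limit leaves unreadable from compound 2 to compound 3. For compound 3 the estimate is 20000 nM, with an expected range from 7000 nM to 40000 nM.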

Compound 3, half-maximal inhibitory concentration: > 4000 nM
Compound 3: a limit, no number; the forecaster's own chance of this, stated with the estimate: 70%; the middle value is on the limit's open side.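

In this assay the entry for compound 3 is a limit, not a number: the limit of > 4000 nM in this assay, at which 1 of the 3 values shown sits.

Even so, a second non-aromatic ring can be compared with the aromatic group of compound 1, and piperidin-1-yl in place of (4-ethylphenyl)amino gives an at least 3.6-fold higher number from compound 1 to compound 3 (0.55 log units; beyond the scatter), so the weaker result seen with pyrrolidin-1-yl also holds for this six-membered ring. The step between the two non-aromatic rings cannot be read, as both entries are limits, and these values do not show whether the five-membered or the six-membered ring is the better of the two.

On these data alone, it remains open which part of the (4-ethylphenyl)amino group matters most: the hydrogen on its nitrogen, the phenyl part or the ethyl chain. A plain phenylamino group, a cyclohexylamino group and an N-methyl-N-(4-ethylphenyl)amino group at this same place would begin to separate these three parts.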